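The source may report more compounds than this note shows. Statements on the series, on what has been measured and on what is new or still open speak of the compounds shown alone.

Values in an ADME assay on cells (Homo sapiens) for cytotoxicity, read by resazurin assay, with a stated time of 5 days; on this read-out higher numbers stand for lower toxicity in this test and lower numbers for higher toxicity in this test:
- Compound 1 `COc1ccc(-c2nc(C(C)S(=O)(=O)c3cccc(Cl)c3)nc3ccsc23)cn1` gives > 50000 nM (a limit)
- Compound 2 `COc1ccc(-c2nc(CS(=O)(=O)c3cccc(Cl)c3)nc3ccsc23)cn1` gives > 10000 nM (a limit)
- Compound 3 `COc1ccc(-c2nc(CSCc3cccc(Cl)c3)nc3ccsc23)cn1` gives > 50000 nM (a limit)

None of these three values is a number; each is a limit of the assay. Compound 2 stands at the limit of > 10000 nM in this assay, at which 1 of the 3 values shown sits. Compound 1 and compound 3 stand at the limit of > 50000 nM in this assay, at which 2 of the 3 values shown sit.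

Compound 4 `O=S(=O)(Cc1nc(-c2ccnc(Cl)c2)c2sccc2n1)c1cccc(Cl)c1` has 2-chloropyridin-4-yl in place of 6-methoxypyridin-3-yl on an aromatic carbon of the shared core, and the count of that change is 2-chloropyridin-4-yl in place of 6-methoxypyridin-3-yl on an aromatic carbon.

Going by the values given here, only one measured step exists, and it lies elsewhere in the structure: a step that the two limits leave unreadable from compound 1 to compound 2, with hydrogen in place of methyl on a saturated chain carbon bound to an aromatic carbon and a sulfonyl sulfur. It has no readable size, and it says nothing directly about the exchange in compound 4. The expectation therefore rests on the three limits alone. No step beyond the scatter is expected in this assay, in either direction, although this is weakly founded. The estimated step is a step that the limit leaves unreadable from compound 2 to compound 4. For compound 4 the expected value is 30000 nM, with an estimated range from 10000 nM to 50000 nM.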

Compound 4, half-maximal cytotoxic concentration: 63000 nM
For compound 4 the middle estimate is 2.1-fold (0.32 log units) below the measured one; the whole stated range lies below it.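

In this assay no step can be read from compound 2 to compound 4. Compound 2 gives > 10000 nM, which is a limit and not a number. The compounds shown leave open how large the effect of 2-chloropyridin-4-yl in place of 6-methoxypyridin-3-yl on an aromatic carbon is in this assay, and in which direction it runs.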